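The source may report more compounds than this note shows. Statements on the series, on what has been measured and on what is new or still open speak of the compounds shown alone.

Measured so far in an assay on isolated protein for inhibition of Amine oxidase [flavin-containing] B (Homo sapiens), read by fluorescence and Amplex Red, with stated times of 15 min and 20 min; on this read-out lower numbers stand for stronger inhibition and higher numbers for weaker inhibition:

- compound 1, `Oc1ccc(O)c(/C=N/c2ccc(OCc3ccccc3)cc2)c1`: 1230 nM
- compound 2, `Oc1cc(O)c(/C=N/c2ccc(OCc3ccccc3)cc2)c(O)c1`: 10100 nM

Of the two numbers recorded so far, compound 1 stands lowest. Among the compounds with values here, compound 2 sits above it by a margin that exceeds the usual scatter; no step between the two has been worked out, so only the two values themselves are noted here.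

The step considered next runs from compound 1 to compound 3, `Cc1ccc(O)c(/C=N/c2ccc(OCc3ccccc3)cc2)c1`. The change is methyl in place of hydroxy on an aromatic carbon meta to a large group and para to a hydroxy group; in the wider reading, 2,5-dihydroxyphenyl becomes 2-hydroxy-5-methylphenyl.

Within the data shown here, no measured step in this assay matches this exchange, so the expectation rests on compound 1 alone. A small step is expected, likely toward a somewhat lower number, though one that may still lie within the scatter. The expected step from compound 1 to compound 3 is a 1.8-fold lower number from compound 1 to compound 3 (0.24 log units; within the scatter). Compound 3 is estimated at 700 nM, within 150 nM to 3000 nM.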

Compound 3, half-maximal inhibitory concentration: 24600 nM
For compound 3 the middle estimate is 35-fold (1.55 log units) below the measured one; measured number above the stated range.
By their numbers in this assay, from the lowest: compound 1; then compound 2; then compound 3.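

In this assay, the place meta to a large group and para to a hydroxy group is far from indifferent to what it carries: methyl in place of hydroxy there gives a 20-fold higher number from compound 1 to compound 3 (1.30 log units; beyond the scatter). Within the data shown here, this is the first exchange made at one place alone, and it ties the lower number of compound 1 to the hydroxy of the 2,5-dihydroxyphenyl group, a tie the two earlier values could not show on their own. Nothing at hand gives a measured reason for the size of this step.

On these data alone, with one exchange at this place, the step cannot be divided between the departure of hydroxy and the arrival of methyl, and it remains open whether an amine, a methoxy group or plain hydrogen there would stay close to compound 1 at 1230 nM. Among these compounds, it is also open whether the same exchange would produce a step of similar size on other hydroxy-bearing rings, such as the one in compound 2.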